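The compounds below may be only part of what the source reports. "The series", "measured", "known", "first", "only" and "open" are said of these compounds alone.

Measured in a functional assay on CCRF-CEM cells (Homo sapiens) for antiproliferative activity, with a stated time of 72 h; a lower number here means that less compound is needed, a higher number that more compound is needed for the effect:
Compound 1 `Cc1cn([C@@H]2O[C@H](CO)[C@@H](CN=[N+]=[N-])[C@@H]2O)c(=O)[nH]c1=O`: > 100 uM, a limit and not a number
Compound 2 `Cc1cn([C@@H]2O[C@H](CO)[C@@H](CN)[C@@H]2O)c(=O)[nH]c1=O`: > 100 uM, a limit and not a number

Compound 2 therefore has no exact value in this assay, and the data show (the limit of > 100 uM in this assay, at which 2 of the 2 values shown sit). Compound 3 `Cc1cn([C@@H]2O[C@H](CO)[C@@H](CF)[C@@H]2O)c(=O)[nH]c1=O` differs from it by fluoro in place of amino on a saturated chain carbon bound to a saturated ring carbon; in words, fluoro in place of amino on a saturated chain carbon bound to a saturated ring carbon.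

For the measured compounds named here, one measured step bears on this change, as it also alters the group at that place: a step that the two limits leave unreadable from compound 1 to compound 2. It offers no size to carry over. The expectation therefore starts from compound 2 at > 100 uM, with no step beyond the scatter expected in this assay and no direction predicted. A further limit is the likeliest report for compound 3.

The estimated change is a number no higher from compound 2 to compound 3 (the limit leaves the size open). The expected value for compound 3 is 100 uM, within an estimated range of 40 uM to 250 uM.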

Compound 3, concentration for half-maximal effect: > 100 uM
Compound 3: no number, only a limit; the forecaster's own chance of this, stated with the estimate: 80%; the middle value sits exactly at the limit.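

No step can be read among compound 1, compound 2 and compound 3, as each is reported only as a limit: the limit of > 100 uM in this assay, at which 3 of the 3 values shown sit. The compounds shown leave open whether azido, amino or fluoro on this saturated chain carbon makes any difference to antiproliferative activity in this assay.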